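Oxazolyl to methylpyridinyl swap on the ether carbon

The source may report more compounds than this note shows. Statements on the series, on what has been measured and on what is new or still open speak of the compounds shown alone.

Measured compounds in an assay for inhibition of kynurenine 3-monooxygenase (Homo sapiens), read by mass spectrometry, with a stated time of 1 h; on this read-out higher numbers stand for weaker inhibition and lower numbers for stronger inhibition:
- Compound 1 `Cc1ccc([C@@H](C)Oc2cc3oc(=O)n(CCC(=O)O)c3cc2Cl)nc1`: 3.16 nM
- Compound 2 `C[C@@H](Oc1cc2oc(=O)n(CCC(=O)O)c2cc1Cl)c1cccnn1`: 1.26 nM
- Compound 3 `C[C@@H](Oc1cc2oc(=O)n(CCC(=O)O)c2cc1Cl)c1ncco1`: 3.16 nM

Compound 3 sits level with compound 1 at the digits shown; together these two carry the highest numbers of the three, and the nearest is compound 1 with no change at the digits printed from compound 1 to compound 3 (within the scatter). The furthest is compound 2, with a 2.5-fold higher number from compound 2 to compound 3 (0.40 log units; beyond the scatter).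

Compound 4 `Cc1ccnc([C@@H](C)Oc2cc3oc(=O)n(CCC(=O)O)c3cc2Cl)c1` is not yet measured. Against compound 3 the change is 4-methylpyridin-2-yl in place of 1,3-oxazol-2-yl on a saturated chain carbon bound to an oxygen on an aromatic ring and a saturated chain carbon.

For the measured compounds named here, two measured steps bear on this. From compound 1 to compound 3 a methylpyridinyl group gave way to the oxazolyl group with no change at the digits printed from compound 1 to compound 3 (within the scatter); compound 4 reverses that kind of exchange, bringing in another methylpyridinyl group, so no step beyond the scatter is expected. Going by the values given here, the only clearly sized step in the set, a 2.5-fold higher number from compound 2 to compound 3 (0.40 log units; beyond the scatter), involves the pyridazinyl group of compound 2, which compound 4 does not carry, so it is not expected to repeat here.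

Compound 4 is therefore expected to come out at 3 nM, between 1.3 nM and 7 nM, meaning a step of a 1.1-fold lower number from compound 3 to compound 4 (0.02 log units; within the scatter).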

Compound 4, half-maximal inhibitory concentration: 3.98 nM
The estimate for compound 4 lay 1.3-fold (0.12 log units) below the measured number, and the stated range covers the measured number.
By their numbers in this assay, from the lowest: compound 2; then compounds 1, 3 and 4 (each within the scatter of the next).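

In this assay the carbon bound to the aromatic ether oxygen accepts the 4-methylpyridin-2-yl group in place of 1,3-oxazol-2-yl with a 1.3-fold higher number from compound 3 to compound 4 (0.10 log units; within the scatter), so going from the five-membered ring to the methylated six-membered ring leaves the number within the scatter. The 4-methylpyridin-2-yl and 5-methylpyridin-2-yl groups also stay within the scatter, with a 1.3-fold higher number from compound 1 to compound 4 (0.10 log units; within the scatter), so no effect of the methyl placement can be read from this pair. The new comparison with pyridazin-3-yl, a 3.2-fold higher number from compound 2 to compound 4 (0.50 log units; beyond the scatter), leaves compound 2 with the lowest number of the four, its steps to compounds 1, 3 and 4 all beyond the scatter.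

No measurement shown here explains why compound 2 stands apart. On these data alone, whether a pyrimidin-2-yl or an unsubstituted pyridin-2-yl group at this carbon would match compound 2 or the other three remains open.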